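Trading cyclopentyl for methyl on a nitrogen

The compounds below may be only part of what the source reports. "The series", "measured", "known", "first", "only" and "open" are said of these compounds alone.

In a functional assay on KBVIN cells (Homo sapiens) for antiproliferative activity, read by sulforhodamine B assay, with a stated time of 48 h (on this read-out higher numbers stand for weaker inhibition of growth and lower numbers for stronger inhibition of growth), compound 1 (`COc1ccc(Nc2nc(NC3CCCC3)c3ccccc3n2)cc1`) gives 12600 nM while compound 2 (`CNc1nc(Nc2ccc(OC)cc2)nc2ccccc12`) gives 17500 nM and compound 3 (`COc1ccc(N(C)c2nc(NC3CCCC3)c3ccccc3n2)cc1`) gives 10100 nM and these three values all lie within the usual scatter of one another. Compound 3 therefore cannot be ranked against the other two on these numbers.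

Compound 4 (`CNc1nc(N(C)c2ccc(OC)cc2)nc2ccccc12`) differs from compound 3 in one place (methyl in place of cyclopentyl on a nitrogen on an aromatic ring), with methyl in place of cyclopentyl on a nitrogen on an aromatic ring.

Going by the values given here, two measured steps bear on this change. The same exchange of cyclopentyl for methyl has already been measured once, as a 1.4-fold higher number from compound 1 to compound 2 (0.14 log units; within the scatter) in this assay and this is the closest guide available. The other step, methyl in place of hydrogen on a nitrogen on an aromatic ring, appears as a 1.2-fold lower number from compound 1 to compound 3 (0.10 log units; within the scatter) and it links compound 3 to that earlier comparison. Neither step leaves the scatter, so no change beyond the scatter is expected here, at most a slight drift in the same direction as the first step.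

The estimated step is a 1.4-fold higher number from compound 3 to compound 4 (0.14 log units; within the scatter) and it is expected to stay small. The estimated value for compound 4 is 14000 nM with an expected range of 7500 nM to 26000 nM on this evidence.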

Compound 4, concentration for 50% growth inhibition: 22900 nM
Compound 4: the middle estimate sits 1.6-fold (0.21 log units) below what was measured; the range from low to high includes it.
By their numbers in this assay, from the lowest: compounds 3, 1, 2 and 4 (each within the scatter of the next, the first and the last beyond it).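

Exchanging cyclopentyl for methyl on this nitrogen gives a 2.3-fold higher number from compound 3 to compound 4 (0.36 log units; beyond the scatter) in this assay, so the exchange now leaves the scatter, which the earlier step on the other core did not do. The two steps point the same way and do not truly disagree in size, so they can be read as one modest shift to higher numbers, although two steps are a thin basis: the same change on two cores in this assay, a 1.4-fold higher number (0.14 log units; within the scatter) from compound 1 to compound 2 and a 2.3-fold higher number (0.36 log units; beyond the scatter) from compound 3 to compound 4, 1.6-fold (0.21 log units) apart, within the scatter of two such steps. Methyl in place of hydrogen on a nitrogen on an aromatic ring gives a 1.3-fold higher number from compound 2 to compound 4 (0.12 log units; within the scatter), which is again too small to read, so this change still shows no measurable effect with either cyclopentylamino or methylamino in the molecule: the same change on two cores in this assay, a 1.2-fold lower number (0.10 log units; within the scatter) from compound 1 to compound 3 and a 1.3-fold higher number (0.12 log units; within the scatter) from compound 2 to compound 4, 1.6-fold (0.21 log units) apart, within the scatter of two such steps.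

Only cyclopentyl and methyl are compared at this position, so the compounds shown cannot tell whether the shift follows the ring itself or simply the number of carbons. A straight propyl chain, a larger cyclohexyl ring or a chain ending in an amine on the same nitrogen could separate these readings and show whether the numbers can move further in either direction.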